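Extending a methoxy to an ethoxy on a sulfonium chain

The source may report more compounds than this note shows. Statements on the series, on what has been measured and on what is new or still open speak of the compounds shown alone.

Going by the values given here, compound 2, `CO[C@@H](CO)[C@H](O)C[S@+]1C[C@@H](O)[C@H](O)[C@H]1CO`, is one of two compounds measured in an assay on isolated protein for inhibition of lysosomal alpha-glucosidase (Rattus norvegicus), with a stated time of 30 min; on this read-out higher numbers stand for weaker inhibition and lower numbers for stronger inhibition. In this assay compound 2 gives 5300 nM, and its only companion, compound 1, `[O-][C@@H](CO)[C@H](O)C[S@+]1C[C@@H](O)[C@H](O)[C@H]1CO`, gives 8000 nM; the two numbers sit within the scatter of each other, so neither compound can be set apart from the other. Compound 3, `CCO[C@@H](CO)[C@H](O)C[S@+]1C[C@@H](O)[C@H](O)[C@H]1CO`, has not yet been measured. It differs from compound 2 by methyl in place of hydrogen on a saturated chain carbon bound to an oxygen on a saturated carbon. Among the compounds with values here, the one measured step that bears on this site is a 1.5-fold lower number from compound 1 to compound 2 (0.18 log units; within the scatter), where a hydroxyl became a methoxy without moving the number beyond the scatter. Growing that methoxy further to an ethoxy gives no reason to expect a change beyond the scatter either, so compound 3 is estimated to lie near compound 2 with a step of a 1.1-fold lower number from compound 2 to compound 3 (0.03 log units; within the scatter). The estimate for compound 3 is 5000 nM, with a range from 2000 nM to 13000 nM.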

Compound 3, half-maximal inhibitory concentration: 1700 nM
Compound 3: middle estimate off by 2.9-fold (0.47 log units), on the high side, and the stated range ends above it.
By their numbers in this assay, from the lowest: compound 3; then compounds 2 and 1 (each within the scatter of the next).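

In this assay, going by these compounds alone, the added methyl gives the first step at this position that lies beyond the scatter: a 3.1-fold lower number from compound 2 to compound 3 (0.49 log units; beyond the scatter). Measured from the single oxygen atom, the ethoxy group gives a 4.7-fold lower number from compound 1 to compound 3 (0.67 log units; beyond the scatter), while the methoxy group gave only a 1.5-fold lower number from compound 1 to compound 2 (0.18 log units; within the scatter), which lies within the scatter. The position therefore responds to this change, and among these compounds the response becomes readable only with the ethoxy group; no supporting measurement accounts for this step.

On these data alone, whether a longer chain such as propoxy or butoxy would extend the trend or reverse it remains open. So does the outcome of placing an amine or a carboxylic acid at the end of the ethyl chain.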